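Swapping 2-chlorophenyl for 4-methylphenyl at the assay limit

The source may report more compounds than this note shows. Statements on the series, on what has been measured and on what is new or still open speak of the compounds shown alone.

In a functional assay on U-251 cells (Homo sapiens) for cytotoxicity, read by MTT assay, with a stated time of 48 h (on this read-out higher numbers stand for lower toxicity in this test and lower numbers for higher toxicity in this test), compound 1 `O=C1Nc2ccccc2/C1=N/NC(=S)N1CCN(C(=O)NO)CC1` gives > 100000 nM as a limit and not a number. Compound 2 `O=C(NO)N1CCN(C(=S)N/N=C/c2ccccc2O)CC1` gives > 100000 nM which is also a limit. Compound 3 `O=C(NO)N1CCN(C(=S)N/N=C/c2ccccc2Cl)CC1` stands at > 100000 nM and this too is only a limit. Compound 4 `Cc1ccc(/C=N/NC(=S)N2CCN(C(=O)NO)CC2)cc1` differs from it by 4-methylphenyl in place of 2-chlorophenyl on a carbon with a double bond to nitrogen and so carries 4-methylphenyl in place of 2-chlorophenyl on a carbon with a double bond to nitrogen. Within the data shown here, the one measured step that bears on this is a step that the two limits leave unreadable from compound 2 to compound 3 and it offers no size. Among the measured compounds shown here, with the limit of > 100000 nM in this assay, at which 3 of the 3 values shown sit, as the only guide, the expected outcome is a number no higher from compound 3 to compound 4 (the limit leaves the size open) with no direction to be read. For compound 4 the estimate is 100000 nM with an expected range from 50000 nM to 200000 nM in this assay as its likely result.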

Compound 4, concentration lethal to 50% of the cells: > 100000 nM
Compound 4 gave a limit, no number; the forecaster's own chance of this, stated with the estimate: 85%; the middle value sits exactly at the limit.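

In this assay compound 4 gives > 100000 nM, a limit and not a number, and its steps from compound 2 and from compound 3 cannot be read. The compounds shown leave open whether exchanging these aromatic groups changes the toxicity in this assay at all.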